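A few compounds are considered here, and "the series" means these few. Any claim that something is new, unique, unknown or untested is made for them only; others in the source may bear on it.

In a functional assay on A549 cells (Homo sapiens) for inhibition, read by MTT assay, with a stated time of 24 h (a higher number here means a weaker inhibitor, a lower number a stronger inhibitor), compound 2 `CC1(C)[C@H]2CC[C@]1(C)N(Cc1cn(-c3cccc(F)c3)nn1)C(=O)C2` gives 180 nM, the higher of the two numbers recorded so far. Its nearest neighbour is compound 1 `CC1(C)[C@H]2CC[C@]1(C)N(Cc1cn(-c3ccccc3Br)nn1)C(=O)C2`, which in this assay gives 130 nM; the step of a 1.4-fold higher number from compound 1 to compound 2 (0.14 log units; within the scatter) separates them, a change of 3-fluorophenyl in place of 2-bromophenyl on an aromatic nitrogen that stays within the scatter. Compound 3 `Cc1cccc(-n2cc(CN3C(=O)C[C@@H]4CC[C@@]3(C)C4(C)C)nn2)c1` differs from compound 2 by methyl in place of fluoro on an aromatic carbon. Among the measured compounds shown here, no measured pair exchanges a fluoro for a methyl, so the only guidance is the single step from compound 1 to compound 2, which swapped the substituent on the same aromatic ring and moved the number hardly at all. The step of a 1.1-fold higher number from compound 2 to compound 3 (0.05 log units; within the scatter) is therefore expected to be small, with no clear direction beyond the scatter. For compound 3 the estimated value is 200 nM, with an expected range from 80 nM to 500 nM.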

Compound 3, half-maximal inhibitory concentration: 50 nM
Estimate against measurement, compound 3: 4.0-fold (0.60 log units) above; the measured number lies below the stated range.
By their numbers in this assay, from the lowest: compound 3; then compounds 1 and 2 (each within the scatter of the next).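

This position on the aromatic ring is not indifferent to what it carries: in this assay the exchange of fluoro for methyl brings a 3.6-fold lower number from compound 2 to compound 3 (0.56 log units; beyond the scatter) while the earlier change of substituent had stayed within the scatter. The 3-methylphenyl group also brings a 2.6-fold lower number from compound 1 to compound 3 (0.41 log units; beyond the scatter) when it replaces 2-bromophenyl, so compound 3 gives the lowest number of the three, with steps beyond the scatter to both others. No evidence is available that bears on why methyl and fluoro differ here.

From the compounds shown here alone, whether the lower number is particular to methyl or extends to an ethyl, a methoxy or an amine at this place remains open. Going by these compounds, it is equally open how a plain phenyl, with no substituent on the ring, would compare with these compounds.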